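A few compounds are considered here, and "the series" means these few. Any claim that something is new, unique, unknown or untested is made for them only; others in the source may bear on it.

Of the compounds shown here, three from this series have been tested for antiproliferative activity. Compound 1 `CC(C)=CCc1cc(C(=O)Nc2cc3ccc(OCC4CCN(C)C4)c(C)c3oc2=O)ccc1O` gives 1550 nM in a functional assay on MCF7 cells (Homo sapiens) for antiproliferative activity; on this read-out higher numbers stand for weaker inhibition and lower numbers for stronger inhibition. Compound 2 `CCCNCCCOc1ccc2cc(NC(=O)c3ccc(O)c(CC=C(C)C)c3)c(=O)oc2c1C` gives 980 nM in this assay, and compound 3 `CC(C)=CCc1cc(C(=O)Nc2cc3ccc(OCCCN(C)C(C)C)c(C)c3oc2=O)ccc1O` gives 1050 nM in this assay. Compound 3 thus stands second highest of the three numbers, with compound 2 nearest and compound 1 furthest, and the steps of a 1.5-fold lower number from compound 1 to compound 3 (0.17 log units; within the scatter) and a 1.1-fold higher number from compound 2 to compound 3 (0.03 log units; within the scatter) both lie within the scatter, as does a 1.6-fold lower number from compound 1 to compound 2 (0.20 log units; within the scatter).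

Compound 4 `CC(C)=CCc1cc(C(=O)Nc2cc3ccc(OCCCN(C)c4ccccc4)c(C)c3oc2=O)ccc1O` has not yet been measured. It differs from compound 3 by phenyl in place of isopropyl on an amine nitrogen, on the amine nitrogen whose other neighbours are two saturated chain carbons. The step from compound 2 to compound 3 bears most directly on this change, since it also alters the groups on the amine nitrogen, and it was within the scatter; the step from compound 1 to compound 3 likewise stayed within the scatter. On this basis no change beyond the scatter is expected for compound 4 in this assay, and the expected step is a 1.1-fold lower number from compound 3 to compound 4 (0.02 log units; within the scatter). Compound 4 is estimated at 1000 nM, within a range from 400 nM to 2500 nM.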

Compound 4, half-maximal inhibitory concentration: > 50000 nM
Compound 4 was reported as a limit; the forecaster's own chance of this, stated with the estimate: 5%; at least 50-fold (1.69 log units) between middle value and limit.
By their numbers in this assay, from the lowest: compounds 2, 3 and 1 (each within the scatter of the next). At a limit, above all of these: compound 4.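

In this assay, compound 4 is reported only as a limit and not as a number: the limit of > 50000 nM in this assay, at which 1 of the 4 values shown sits. Earlier changes to the groups on this amine nitrogen and along the chain stayed within the scatter, so they gave no sign that the position could respond at all, yet phenyl in place of isopropyl on the amine nitrogen gives an at least 47-fold higher number from compound 3 to compound 4 (1.67 log units; beyond the scatter). Against the other two compounds the result is of similar size, with an at least 51-fold higher number from compound 2 to compound 4 (1.70 log units; beyond the scatter) and an at least 32-fold higher number from compound 1 to compound 4 (1.50 log units; beyond the scatter), so among the four compounds only the methyl(phenyl)amino group stands apart.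

The compounds shown do not tell whether this loss belongs to the phenyl ring in particular or to any ring on this nitrogen. A cyclohexyl or benzyl group in the same place would separate these readings, and the data give no cause for the step.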